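The source may report more compounds than this note shows. Statements on the series, on what has been measured and on what is new or still open speak of the compounds shown alone.

The measured compounds, all tested in a functional assay on A549 cells (Homo sapiens) for cytotoxicity, read by XTT assay, with a stated time of 24 h; a higher number here means a weaker inhibitor, a lower number a stronger inhibitor:

Compound 1, `Cn1nnnc1SCC(=O)N/N=C/c1ccc(Br)cc1`: in this assay compound 1 gives > 10000000 nM, which is a limit of the assay rather than a number.
Compound 2, `Cn1nnnc1SCC(=O)N/N=C/c1ccc(O)cc1`: in this assay compound 2 gives > 10000000 nM, again a limit of the assay.
Among the measured compounds shown here, compound 3, `Cn1nnnc1SCC(=O)N/N=C/c1cccc(Br)c1`: in this assay compound 3 gives 600000 nM, the only number among the three.

From compound 1 to compound 2 the change is hydroxy in place of bromo on an aromatic carbon. The step it produced, a step that the two limits leave unreadable from compound 1 to compound 2, cannot be read, because the limit of > 10000000 nM in this assay, at which 2 of the 3 values shown sit, covers both ends of it.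

Compound 4, `Cn1nnnc1SCC(=O)N/N=C/c1cccc(O)c1`, is still to be measured. It is made from compound 3 by the same kind of change, (hydroxy in place of bromo on an aromatic carbon). The place differs: in compound 1 and compound 2 the group sits para to a large group, in compound 3 and compound 4 it sits meta to a large group. Compound 1 and compound 3 have the same atoms joined differently; the difference between the two cores is not broken down here.

For the measured compounds named here, the only available precedent for this exchange is unreadable, so the expectation for compound 4 has to rest on the number for compound 3, 600000 nM, with wide uncertainty. Compound 4 is expected to show a step of a 2.5-fold higher number from compound 3 to compound 4 (0.40 log units; beyond the scatter) in this assay. The estimate for compound 4 in this assay is therefore 1500000 nM, with a range from 300000 nM to 8000000 nM.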

Compound 4, half-maximal inhibitory concentration: 4500000 nM
Beside the measured number, compound 4's estimate is 3.0-fold (0.48 log units) below it; the measured number falls inside the stated range.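

In this assay, hydroxy in place of bromo on an aromatic carbon, meta to a large group, gives a 7.5-fold higher number from compound 3 to compound 4 (0.88 log units; beyond the scatter), a modest step toward weaker inhibition on this core. This is one matched pair in one assay, so it shows the direction and size of the exchange at this one place on the core of compound 3, and it does not establish a rule for the series. Whether the step carries over to the core of compound 1 cannot be said, because the only other pair with this exchange, compound 1 and compound 2, cannot be read: the limit of > 10000000 nM in this assay, at which 2 of the 4 values shown sit.

The compounds shown carry only bromo and hydroxy on the aromatic ring, so it remains open how an amine, a carboxylic acid or a longer chain at the same place would read in this assay. Also open, on these data alone, is whether the step from compound 3 to compound 4 would keep its size on a further core, since a single readable pair gives nothing to compare it with.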